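Ring Size at the Hydroxyalkyl Amide Position

This account rests on a few compounds, and the source may have more. Where it says the series, first, only, none or still open, it means among the compounds named here.

Compound 1: `O=C(NCC1(O)CCCCCC1F)c1cc(-c2ncc(F)cn2)ccc1Cl` — 17 nM
Compound 2: `Cc1cnc(-c2ccc(Cl)c(C(=O)NCC3(O)CCCCCC3)c2)cn1` — 22 nM
Compound 3: `Cc1cnc(-c2ccc(Cl)c(C(=O)NCC3(O)CCCCCC3)c2)nc1` — 8 nM

In a functional assay on HEK293 cells for antagonist activity at P2X purinoceptor 7 (Homo sapiens) (a lower number here means a stronger inhibitor, a higher number a weaker inhibitor), compound 1 (`O=C(NCC1(O)CCCCCC1F)c1cc(-c2ncc(F)cn2)ccc1Cl`) gives 17 nM. Compound 2 (`Cc1cnc(-c2ccc(Cl)c(C(=O)NCC3(O)CCCCCC3)c2)cn1`) gives 22 nM, and compound 3 (`Cc1cnc(-c2ccc(Cl)c(C(=O)NCC3(O)CCCCCC3)c2)nc1`) gives 8 nM. Compound 1 thus stands second highest of the three numbers; its gap to compound 2 lies within the scatter, while compound 3 sits a step beyond the scatter below it. Going by the values given here, the one step that can be computed, a 2.8-fold lower number from compound 2 to compound 3 (0.44 log units; beyond the scatter), concerns the aromatic substituent and not the part that changes here.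

Compound 4 (`O=C(NCC1(O)CCCC1)c1cc(-c2ncc(F)cn2)ccc1Cl`) differs from compound 1 in that (1-hydroxycyclopentyl in place of 2-fluoro-1-hydroxycycloheptyl on a saturated chain carbon bound to an amide-type nitrogen). Among the compounds with values here, no measured pair alters the ring bound to the amide-type nitrogen, so no step bears on this change directly. On these data alone, compounds 2 and 3 carry a 1-hydroxycycloheptyl without fluorine and their values sit close to that of compound 1, which suggests the fluorine is not essential, but the smaller ring is untested. The author therefore expects a modest step, with a 2.4-fold higher number from compound 1 to compound 4 (0.37 log units; beyond the scatter) pointing toward a somewhat higher number and wide uncertainty. Compound 4 is estimated at 40 nM, within 10 nM to 160 nM.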

Compound 4, half-maximal inhibitory concentration: 449 nM
Compound 4: middle estimate off by 11-fold (1.05 log units), on the low side, outside the stated range (above it).
By their numbers in this assay, from the lowest: compound 3; then compounds 1 and 2 (each within the scatter of the next); then compound 4.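

Replacing 2-fluoro-1-hydroxycycloheptyl with 1-hydroxycyclopentyl on a saturated chain carbon bound to an amide-type nitrogen gives a 26-fold higher number from compound 1 to compound 4 (1.42 log units; beyond the scatter), so in this assay the group at this position can move the number strongly, and this large step outweighs the modest aromatic change in a 2.8-fold lower number from compound 2 to compound 3 (0.44 log units; beyond the scatter). The two groups have the same hydrogen-bond donor and acceptor counts and no net charge, so those counts do not distinguish them; they differ in ring size, in heavy atoms and in the fluorine. No measurement shown here gives an explanation for this step.

Since the seven-membered ring and the fluorine leave together, the compounds shown do not tell how much of the step belongs to ring size and how much to the loss of fluorine. Also open, on these data alone, are how a 1-hydroxycycloheptyl without fluorine would read on the core of compound 1, and whether a 1-hydroxycyclohexyl would fall nearer to compound 1 or to compound 4 in this assay.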